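Two Chlorines Leave Compound 2

This account rests on a few compounds, and the source may have more. Where it says the series, first, only, none or still open, it means among the compounds named here.

In a functional assay on cells (Cancer cell lines, Homo sapiens) for inhibition (a higher number here means a weaker inhibitor of growth, a lower number a stronger inhibitor of growth), three related compounds have been measured: compound 1 (`Cc1cc(-c2nc3sc(C)cn3c2/C=N/NC(=N)N)c(C)s1` at 12000 nM) and compound 2 (`N=C(N)N/N=C/c1c(-c2cc(Cl)sc2Cl)nc2n1CCS2` at 10500 nM) and compound 3 (`N=C(N)N/N=C/c1c(-c2cccs2)nc2sccn12` at 10200 nM). These numbers lie within the usual scatter of one another, so compound 2 stands level with the other two and no ranking can be drawn.

Compound 4 (`N=C(N)N/N=C/c1c(-c2ccsc2)nc2n1CCS2`) has not yet been measured. It differs from compound 2 in one place, with thiophen-3-yl in place of 2,5-dichlorothiophen-3-yl on an aromatic carbon. Within the data shown here, no measured pair shows this change directly. Compound 3 carries no chlorine and gives 10200 nM in the same range as the chlorinated compound 2, although the two differ elsewhere as well. Compound 1 also has no chlorine and gives 12000 nM within that range too. The expected change is a 1.0-fold higher number from compound 2 to compound 4 (0.02 log units; within the scatter) and would not go beyond the scatter in either direction. For compound 4 the estimated value is 11000 nM (expected range 5000 nM to 24000 nM).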

Compound 4, concentration for 50% growth inhibition: 14500 nM
For compound 4 the middle estimate is 1.3-fold (0.12 log units) below the measured one; the measured number falls inside the stated range.
By their numbers in this assay, from the lowest: compounds 3, 2, 1 and 4 (each within the scatter of the next).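

In this assay, among these compounds, this pair gives the first direct reading of the change at this aromatic carbon: thiophen-3-yl in place of 2,5-dichlorothiophen-3-yl gives a 1.4-fold higher number from compound 2 to compound 4 (0.14 log units; within the scatter). The two chlorines can therefore leave this group with no difference that this measurement can resolve, whereas compound 1 and compound 3 could only hint at this, as each differs from compound 2 elsewhere as well. No measurement is available here to explain this result.

As far as these compounds go, whether a quite different group at this position, such as a phenyl ring or a carboxylic acid, would move the number beyond the scatter remains open. This single pair also cannot say whether a lone chlorine, or the same swap on the core of compound 3, would behave alike.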